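The source may report more compounds than this note shows. Statements on the series, on what has been measured and on what is new or still open speak of the compounds shown alone.

Measured compounds in an assay on HEK293 cells for antagonist activity at transient receptor potential cation channel subfamily M member 8 (Homo sapiens), read by calcium flux; on this read-out lower numbers stand for stronger inhibition and higher numbers for weaker inhibition:
- compound 1 `COC(=O)[C@@H](c1ccccc1)N(Cc1cccc(OC)c1)C(=O)c1ccccc1` gives 210 nM.
- compound 3 `COc1cccc(CN(C(=O)c2cccs2)[C@@H](C(N)=O)c2ccccc2)c1` gives 1700 nM.
- compound 2 `COc1cc(CN(C(=O)c2cccs2)[C@@H](C(N)=O)c2ccccc2)ccc1OCc1ccc(F)cc1` reaches only the assay limit, > 100000 nM.

Compound 1 holds the lowest number of the two that are numbers; compound 3 sits an at least 58-fold lower number from compound 2 to compound 3 (1.76 log units; beyond the scatter) away from the limit of compound 2, and compound 1 sits further below compound 3 still. Compounds 1 and 3 differ in more than one place, so their values are noted side by side without a step being drawn. Among the compounds with values here, the one measured step, (4-fluorobenzyl)oxy to hydrogen on an aromatic carbon, is large and ends at a limit (the limit of > 100000 nM in this assay, at which 1 of the 3 values shown sits), so it gives no size for other changes.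

Compound 4 `COc1cccc(CN(C(=O)c2ccccc2)[C@@H](C(=O)N(C)C)c2ccccc2)c1` is compound 1 with dimethylamino in place of methoxy on a carbonyl carbon: methoxycarbonyl becomes dimethylcarbamoyl. Within the data shown here, no measured step touches this position, so the expectation rests on compound 1 alone and is wide. A step of a 2.1-fold higher number from compound 1 to compound 4 (0.33 log units; beyond the scatter) toward a somewhat higher number is expected for compound 4 in this assay. The estimate for compound 4 is 450 nM, between 100 nM and 2500 nM.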

Compound 4, half-maximal inhibitory concentration: 86000 nM
Beside the measured number, compound 4's estimate is 190-fold (2.28 log units) below it, outside the stated range (above it).
By their numbers in this assay, from the lowest: compound 1; then compound 3; then compound 4. At a limit, above all of these: compound 2.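

In this assay, within the data shown here, the carbonyl carbon position, which no earlier step touched, proves highly sensitive: dimethylamino in place of methoxy gives a 410-fold higher number from compound 1 to compound 4 (2.61 log units; beyond the scatter). With the rest of compound 1 kept, this single change is enough for the loss, so in this pair the low number goes with the methoxycarbonyl group. Unlike the earlier step, this one ends on a number at both sides, and compound 2 remains the only compound at a limit: the limit of > 100000 nM in this assay, at which 1 of the 4 values shown sits.

Going by these compounds, it remains open whether the loss is specific to dimethylamino or follows any replacement of methoxy; an ethoxy group, a methylamino group or a carboxylic acid on the same carbonyl carbon would separate these cases. Compound 3 differs from compound 1 and compound 4 in more than one place, so it cannot settle the question.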